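The source may hold more compounds than are shown below. What is called first, only, known or untested is meant among the compounds shown, and "the series" means these compounds.

In a functional assay on the whole organism with Mus musculus as the target (on this read-out lower numbers stand for smaller maximal responses and higher numbers for larger maximal responses), compound 2 `CCCCCCCCCCn1c(=O)n(C2OC(CO)[C@@H](O)[C@H]2O)c2nc(N)nc(O)c21` gives 0%, and compound 3 `CCCn1c(=O)n(C2CCC(CO)O2)c2nc(NC(=O)C(C)(C)C)nc(O)c21` gives 4%, the two lying within the scatter of each other and both far below compound 1 `CCn1c(=O)n(C2OC(CO)[C@@H](O)[C@H]2O)c2nc(N)nc(O)c21`, which gives 82%. Among the compounds with values here, the only single-place step among the measured compounds is a number 82 percentage points lower from compound 1 to compound 2 (beyond the scatter). Compound 4 `Nc1nc(O)c2c(n1)n(C1OC(CO)[C@@H](O)[C@H]1O)c(=O)n2Cc1ccc(Cl)c(Cl)c1` differs from compound 2 by 3,4-dichlorophenyl in place of nonyl on a saturated chain carbon bound to an aromatic nitrogen. Within the data shown here, no measured pair trades a chain for an aromatic ring on this carbon, so the step from compound 1 to compound 2 is the only guide, and it concerns chain length alone. Because compound 2 gives 0%, little room for a further fall remains, and a step of a number 8 percentage points higher from compound 2 to compound 4 (within the scatter) is expected, within the scatter. Compound 4 is therefore estimated at 8%, range 0% to 35%.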

Compound 4, largest response reached (reported as maximal response), in percent of the reference or control that the assay uses: 0%
Beside the measured number, compound 4's estimate is 8 percentage points above it; the range from low to high includes it.
By their numbers in this assay, from the lowest: compounds 2, 4 and 3 (each within the scatter of the next); then compound 1.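

In this assay, exchanging nonyl for 3,4-dichlorophenyl on a saturated chain carbon bound to an aromatic nitrogen gives no change at the digits printed from compound 2 to compound 4 (within the scatter) as the step, so the low read-out is not confined to the long chain of compound 2. The aromatic group also shows a number 82 percentage points lower from compound 1 to compound 4 (beyond the scatter) as its step, matching the fall seen with the chain in a number 82 percentage points lower from compound 1 to compound 2 (beyond the scatter) as the earlier step. No available evidence explains this result.

As far as these compounds go, the size of group at which the response falls away remains open between compound 1 and these larger substituents. Also open, from the compounds shown here alone, is whether unsubstituted benzyl or a chain ending in an amine or a carboxylic acid would retain the response.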